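From Isopropyl to Butyl on the Sulfur

A few compounds are considered here, and "the series" means these few. Any claim that something is new, unique, unknown or untested is made for them only; others in the source may bear on it.

In an ADME assay on MT4 cells (Homo sapiens) for activation, read by MTT assay (a higher number here means that more compound is tolerated, a lower number that less compound is tolerated), compound 1 (`Cc1c(Cc2c(F)cccc2Cl)nc(SC(C)C)[nH]c1=O`) gives > 76000 nM, which is a limit. In this assay compound 2 (`Cc1c(C(C)c2c(F)cccc2Cl)nc(SC(C)C)[nH]c1=O`) gives > 15000 nM, which is also a limit, so compound 2 has no exact number to stand on. Among the measured compounds shown here, the only measured step is a step that the two limits leave unreadable from compound 1 to compound 2. That step places methyl in place of hydrogen on a saturated chain carbon bound to two aromatic carbons, and it supplies no size to carry forward.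

Compound 3 (`CCCCSc1nc(C(C)c2c(F)cccc2Cl)c(C)c(=O)[nH]1`) has butyl in place of isopropyl on a sulfur. For the measured compounds named here, no measured step involves that sulfur, so the data give no firm direction. In this assay the expected step is a step that the limit leaves unreadable from compound 2 to compound 3, and nothing beyond the scatter is expected. For compound 3 the estimate is 25000 nM, with an expected range from 8000 nM to 90000 nM.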

Compound 3, half-maximal cytotoxic concentration: > 1500 nM
Compound 3 ended at the assay's limit (the forecaster's own chance of this, stated with the estimate: 60%); the middle value lies beyond the limit too.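

In this assay compound 3 gives > 1500 nM, which is a limit. Compound 2 also stands at a limit, so no step can be read between compound 2 and compound 3. The compounds shown leave open whether butyl in place of isopropyl on a sulfur changes the tolerated concentration at all.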